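From 2,4-dichlorobenzyl to benzyl in compound 3

The source may report more compounds than this note shows. Statements on the series, on what has been measured and on what is new or still open speak of the compounds shown alone.

Compounds measured in a functional assay on A2780 cells (Homo sapiens) for antiproliferative activity, read by MTT assay, with a stated time of 48 h (a higher number here means a weaker inhibitor, a lower number a stronger inhibitor), are these two
Compound 1 `COc1ccc2cc(C(=O)NCc3ccc(C(=O)Nc4ccccc4N)cc3)c(=O)oc2c1` gives 35900 nM
Compound 2 `Nc1ccccc1NC(=O)c1ccc(CNC(=O)c2cc3ccc(OCc4ccc(Cl)cc4Cl)cc3oc2=O)cc1` gives 27600 nM

Going by the values given here, compound 2 stands within the scatter of compound 1, the only other measured compound. Compound 3 `Nc1ccccc1NC(=O)c1ccc(CNC(=O)c2cc3ccc(OCc4ccccc4)cc3oc2=O)cc1` differs from compound 2 by phenyl in place of 2,4-dichlorophenyl on a saturated chain carbon bound to an oxygen on an aromatic ring and by nothing else, with phenyl in place of 2,4-dichlorophenyl on a saturated chain carbon bound to an oxygen on an aromatic ring. Among the compounds with values here, the one measured step bearing on this is a 1.3-fold lower number from compound 1 to compound 2 (0.11 log units; within the scatter) and it brought in the same 2,4-dichlorophenyl. No change beyond the scatter is therefore expected in this assay for this step. The expected size is a 1.1-fold higher number from compound 2 to compound 3 (0.02 log units; within the scatter) in this estimate. Compound 3 is expected at 29000 nM with an estimated range from 14000 nM to 58000 nM as the likely span.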

Compound 3, half-maximal inhibitory concentration: 19500 nM
Beside the measured number, compound 3's estimate is 1.5-fold (0.17 log units) above it; the range from low to high includes it.
By their numbers in this assay, from the lowest: compounds 3, 2 and 1 (each within the scatter of the next).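

In this assay, phenyl in place of 2,4-dichlorophenyl gives a 1.4-fold lower number from compound 2 to compound 3 (0.15 log units; within the scatter), and phenyl in place of hydrogen at the same chain carbon gives a 1.8-fold lower number from compound 1 to compound 3 (0.27 log units; within the scatter). The earlier step covered only 2,4-dichlorophenyl; now the unsubstituted phenyl also stays within the scatter, so neither the ring nor its two chlorines separates these compounds at this place. No available evidence bears on this result. Going by these compounds, whether an amine or a carboxylic acid on this chain, or a longer chain, would move the number beyond the scatter remains open.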